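This account rests on a few compounds, and the source may have more. Where it says the series, first, only, none or still open, it means among the compounds named here.

In a functional assay on DU-145 cells (Homo sapiens) for inhibition, read by trypan blue exclusion, with a stated time of 96 h (on this read-out higher numbers stand for weaker inhibition of growth and lower numbers for stronger inhibition of growth), compound 1 (`Cc1ccc(S/C(=C/c2ccc(F)c(C)c2)C(=O)c2ccc(Br)cc2)cc1`) gives 25000 nM as its concentration for growth inhibition. Among the measured compounds shown here, the only other measured compound, compound 2 (`O=C(/C(=C\c1c(O)cc(O)cc1O)S(=O)(=O)c1ccccc1Br)c1ccc(Cl)cc1`), gives 50000 nM in this assay and the two values lie within the usual scatter of each other, which places compound 1 level with its one neighbour on these numbers.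

Compound 3 (`CSc1ccc(/C=C(/Sc2ccc(C)cc2)C(=O)c2ccc(Br)cc2)cc1`) has yet to be measured in this assay and keeps the rest of compound 1 unchanged. It carries 4-(methylsulfanyl)phenyl in place of 4-fluoro-3-methylphenyl on a double-bonded chain carbon bound to a double-bonded chain carbon. For the measured compounds named here, no pair of measured compounds differs in one place only, and the data hold no step that speaks to this exchange.

No shift beyond the scatter is expected in this assay in either direction. The expected move is a 1.3-fold lower number from compound 1 to compound 3 (0.10 log units; within the scatter) and it should stay inside that scatter. For compound 3 the estimated value is 20000 nM with an expected range from 6000 nM to 60000 nM across repeated measurements.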

Compound 3, concentration for 50% growth inhibition: 50000 nM
For compound 3 the middle estimate is 2.5-fold (0.40 log units) below the measured one, within the range that was stated.
By their numbers in this assay, from the lowest: compounds 1, 2 and 3 (each within the scatter of the next).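

In this assay, placing 4-(methylsulfanyl)phenyl in place of 4-fluoro-3-methylphenyl on a double-bonded chain carbon bound to a double-bonded chain carbon gives a 2.0-fold higher number from compound 1 to compound 3 (0.30 log units; within the scatter), the first step among these compounds that isolates a change in one place. At this position, then, the two groups cannot be told apart on these numbers, even though the entering group brings sulfur where the leaving group has fluorine and also counts a hydrogen-bond acceptor. Nothing in the data bears on why the exchange leaves the read-out within the scatter.

The compounds shown leave open whether any group at this place can move the number beyond the scatter in either direction, for instance a phenyl ring carrying an amine or a carboxylic acid, or a longer chain in place of the ring. They also leave open whether the same exchange would read alike on a core carrying a different sulfur-linked group or a different group on the carbonyl, since compound 2 differs from the others in more than one place.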